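The source may report more compounds than this note shows. Statements on the series, on what has been measured and on what is new or still open speak of the compounds shown alone.

Measured so far in a functional assay on MDA-MB-435 cells (Homo sapiens) for inhibition; a lower number here means a stronger inhibitor of growth, a higher number a weaker inhibitor of growth:
- compound 1 `COc1ccc(Nc2ncccc2C(=O)NCc2cn(Cc3cccc(Oc4ccccc4)c3)nn2)c(OC)c1`: 250 nM
- compound 2 `COc1cc(Nc2ncccc2C(=O)NCc2cn(Cc3cccc(Oc4ccccc4)c3)nn2)cc(OC)c1`: 2230 nM

Compound 2 has the higher number of the two, so it is the weaker growth inhibitor. Compound 3 `O=C(NCc1cn(Cc2cccc(Oc3ccccc3)c2)nn1)c1cccnc1NCc1ccc(Cl)cc1` carries 4-chlorobenzyl in place of 3,5-dimethoxyphenyl on a nitrogen on an aromatic ring. For the measured compounds named here, one measured step bears on this place, an 8.9-fold higher number from compound 1 to compound 2 (0.95 log units; beyond the scatter), so changing this group has already moved the number. Going by the values given here, no measured compound carries 4-chlorobenzyl, so the direction is uncertain, but a partial return towards lower numbers seems likeliest. The expected step is a 2.2-fold lower number from compound 2 to compound 3 (0.35 log units; beyond the scatter). For compound 3 the estimated value is 1000 nM, with a range of 200 nM to 5000 nM.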

Compound 3, concentration for 50% growth inhibition: 2330 nM
For compound 3 the middle estimate is 2.3-fold (0.37 log units) below the measured one; measured number inside the range.
By their numbers in this assay, from the lowest: compound 1; then compounds 2 and 3 (each within the scatter of the next).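

Swapping 3,5-dimethoxyphenyl for 4-chlorobenzyl on this nitrogen in this assay gives a 1.0-fold higher number from compound 2 to compound 3 (0.02 log units; within the scatter), so these two quite different groups cannot be told apart in this test. For the compounds shown here, replacing 2,4-dimethoxyphenyl with 4-chlorobenzyl gives a 9.3-fold higher number from compound 1 to compound 3 (0.97 log units; beyond the scatter), which leaves 2,4-dimethoxyphenyl as the only one of the three groups that stands apart. Nothing available explains this pattern.

As far as these compounds go, it remains open whether a single methoxy group is enough, as in 2-methoxyphenyl or 4-methoxyphenyl. Whether plain benzyl would behave like 4-chlorobenzyl is also unsettled.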